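Capping the Phenol: From Compound 2 to Compound 3

The compounds below may be only part of what the source reports. "The series", "measured", "known", "first", "only" and "open" are said of these compounds alone.

Compound 1 `O=C(Nc1cccc(Cl)c1)c1cccc(Br)c1` is an amide that joins two substituted benzene rings. In an assay on isolated protein for inhibition of thiosulfate sulfurtransferase (Homo sapiens), with a stated time of 60 min, in the absence of a further agent (on this read-out higher numbers stand for weaker inhibition and lower numbers for stronger inhibition), compound 1 gives > 100000 nM, which is a limit of the assay and not a number. Compound 2 `O=C(Nc1cccc(Cl)c1)c1cc(Br)ccc1O` carries a hydroxy in place of hydrogen on an aromatic carbon. In this assay compound 2 gives > 100000 nM, again a limit rather than a measured number. The step that the two limits leave unreadable from compound 1 to compound 2 therefore cannot be read. On the numbers shown, compound 2 stands at that limit, where both measured values sit (the limit of > 100000 nM in this assay, at which 2 of the 2 values shown sit).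

Compound 3 `COc1ccc(Br)cc1C(=O)Nc1cccc(Cl)c1` differs from compound 2 by methyl in place of hydrogen on an oxygen on an aromatic ring. Among the measured compounds shown here, the only measured step, from compound 1 to compound 2, is unreadable, so it offers no direction for the change to compound 3. With both known compounds sitting at the limit, compound 3 is expected to stay there as well, and the step that the limit leaves unreadable from compound 2 to compound 3 is estimated to be nothing beyond the scatter. Compound 3 is therefore estimated at 150000 nM, within 30000 nM to 600000 nM, and most likely reported once more only as a limit.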

Compound 3, half-maximal inhibitory concentration: > 100000 nM
Compound 3 was reported as a limit; the forecaster's own chance of this, stated with the estimate: 85%; the middle value lies beyond the limit too.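

In this assay compound 3 gives > 100000 nM as a limit of the assay and not a number. No new step can be read among compound 1, compound 2 and compound 3, as all three sit at one limit: (the limit of > 100000 nM in this assay, at which 3 of the 3 values shown sit). The compounds shown leave open whether hydrogen, hydroxy or methoxy at this place changes inhibition at all.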